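Cytotoxicity on the shared core: from compound 2 to compound 3

The compounds below may be only part of what the source reports. "The series", "measured", "known", "first", "only" and "open" are said of these compounds alone.

Measured compounds:
compound 1 `CC(C)C[C@]1(O)NC(=O)[C@]2(OC(Cc3ccccc3)=CC2=O)[C@H]1O` — > 50000 nM
compound 2 `Cc1cc2c(c(=O)[nH]1)OC(C(=O)CC(C)C)O2` — > 50000 nM

In an ADME assay on HEK293 cells (Homo sapiens) for cytotoxicity, read by WST assay, with a stated time of 48 h (a lower number here means a stronger inhibitor, a higher number a weaker inhibitor), compound 1 gives only a limit, > 50000 nM. In this assay compound 2 likewise gives only a limit, > 50000 nM. For the measured compounds named here, both values therefore sit at the same boundary (the limit of > 50000 nM in this assay, at which 2 of the 2 values shown sit), and no step between measured compounds can be read. Compound 3 `CC(C)CC(=O)C1Oc2cc(Cc3ccccc3)[nH]c(=O)c2O1` differs from compound 2 by phenyl in place of hydrogen on a saturated chain carbon bound to an aromatic carbon. With both measured values at the limit, no step beyond the scatter is expected for compound 3; the expected move a step that the limit leaves unreadable from compound 2 to compound 3 is none. Compound 3 is expected to give 60000 nM, most likely again reported only as a limit, with a range of 30000 nM to 150000 nM.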

Compound 3, half-maximal inhibitory concentration: > 50000 nM
Compound 3 ended at the assay's limit; the forecaster's own chance of this, stated with the estimate: 85%; the middle value is on the limit's open side.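

In this assay compound 3 gives > 50000 nM, which is a limit. No step from compound 2 to compound 3 can be read: the limit of > 50000 nM in this assay, at which 3 of the 3 values shown sit.

The compounds shown leave open whether any change on the shared core gives a measurable value in this assay.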